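Biphenyl amide on a fluorinated naphthol ether core

The source may hold more compounds than are shown below. What is called first, only, known or untested is meant among the compounds shown, and "the series" means these compounds.

Compound 1 `O=C(COc1ccc2cc(C(O)(C(F)(F)F)C(F)(F)F)c(O)cc2c1)Nc1ccccc1` is read in an assay on isolated protein for inhibition of receptor-type tyrosine-protein phosphatase C (Homo sapiens), read by spectrophotometry; a higher number here means a weaker inhibitor, a lower number a stronger inhibitor; for compound 1 the value > 20000 nM is a limit of the assay, not a number (the limit of > 20000 nM in this assay, at which 1 of the 3 values shown sits).
Compound 2 `Cc1ccc(S(=O)(=O)NNC(=O)COc2ccc3cc(C(O)(C(F)(F)F)C(F)(F)F)c(O)cc3c2)cc1` gives 16100 nM.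
Compound 3 `O=C(COc1ccc2cc(C(O)(C(F)(F)F)C(F)(F)F)c(O)cc2c1)Nc1cccc2ccccc12` gives 29100 nM.

Among the two numbers, compound 3 stands highest, with compound 2 nearest: the step of a 1.8-fold higher number from compound 2 to compound 3 (0.26 log units; within the scatter) lies within the scatter. The step that the limit leaves unreadable from compound 1 to compound 3 cannot be read. Compound 4 `O=C(COc1ccc2cc(C(O)(C(F)(F)F)C(F)(F)F)c(O)cc2c1)Nc1ccc(-c2ccccc2)cc1` differs from compound 3 by 4-phenylphenyl in place of naphthalen-1-yl on an amide-type nitrogen. The measured swaps of aryl groups on this nitrogen gave either a change within the scatter or one hidden by the limit, so the step of a 1.2-fold lower number from compound 3 to compound 4 (0.07 log units; within the scatter) is expected to be no larger than the scatter. Compound 4 is therefore estimated at 25000 nM, between 10000 nM and 60000 nM.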

Compound 4, half-maximal inhibitory concentration: 3400 nM
Beside the measured number, compound 4's estimate is 7.4-fold (0.87 log units) above it, and the stated range ends above it.
By their numbers in this assay, from the lowest: compound 4; then compounds 2 and 3 (each within the scatter of the next).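

In this assay, within the data shown here, the amide-type nitrogen proves sensitive to which aryl group it carries: 4-phenylphenyl in place of naphthalen-1-yl gives the first readable step beyond the scatter (an 8.6-fold lower number from compound 3 to compound 4 (0.93 log units; beyond the scatter)), although both groups hold two six-membered aromatic rings. Compound 4 also separates from the sulfonyl compound (a 4.7-fold lower number from compound 2 to compound 4 (0.68 log units; beyond the scatter)), and adding phenyl to the phenyl amide gives a step with only a floor (an at least 5.8-fold lower number from compound 1 to compound 4 (0.76 log units; beyond the scatter)). The value of compound 1 is a limit, not a number: the limit of > 20000 nM in this assay, at which 1 of the 4 values shown sits.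

Going by these compounds, whether a carboxylic acid or an amine on the added phenyl would shift the number stays open.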